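The source may report more compounds than this note shows. Statements on the series, on what has been measured and on what is new or still open speak of the compounds shown alone.

Compound 1 `C[C@H](NC(=O)Nc1cccc(F)c1)c1ccccc1` gives 97% in an ADME assay on the whole organism with Oryza sativa as the target, tested at 0.1 uM; on this read-out lower numbers stand for a stronger effect and higher numbers for a weaker effect at the one concentration tested.
Compound 2 `C[C@@H](NC(=O)Nc1ccc(F)cc1)c1ccccc1` gives 98% in this assay.
Compound 3 `C[C@H](NC(=O)Nc1cccc(Br)c1)c1ccccc1` gives 100% in this assay.

All three numbers lie within the scatter of one another, so none of the compounds can be set apart from the others. The change from compound 1 to compound 3 is bromo in place of fluoro on an aromatic carbon, and in this assay it made a number 3 percentage points higher from compound 1 to compound 3 (within the scatter). Compound 2 shares its atoms with compound 1 but has them joined differently; the difference between the two cores is not broken down here.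

Compound 4 `C[C@@H](NC(=O)Nc1ccc(Br)cc1)c1ccccc1` is not yet measured. From compound 2 it differs by bromo in place of fluoro on an aromatic carbon, the same kind of change as from compound 1 to compound 3, though here the group stands para to a large group rather than meta to a large group. The step in this assay is expected to be a number 1 percentage points higher from compound 2 to compound 4 (within the scatter), in line with the earlier step, because a number 3 percentage points higher from compound 1 to compound 3 (within the scatter) stayed within the scatter. Compound 4 is therefore estimated at 99%, expected to fall between 92% and 100%.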

Compound 4, a percentage reported as activity, at one concentration (the size of the read-out at that concentration, not a potency): 100%
Estimate against measurement, compound 4: 1 percentage points below; low and high end bracket the measured number.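

Bromo in place of fluoro on an aromatic carbon made a number 2 percentage points higher from compound 2 to compound 4 (within the scatter) in this assay. Set beside the earlier step, the change behaves alike on the two cores: the same change on two cores in this assay, a number 3 percentage points higher (within the scatter) from compound 1 to compound 3 and a number 2 percentage points higher (within the scatter) from compound 2 to compound 4, 1 percentage points apart, within the scatter of two such steps. Among these compounds, both steps lie within the scatter, so this agreement shows only that the change had no measurable effect on either core, not that a real effect of the change would carry from one core to another.

The compounds shown carry only fluoro and bromo on this ring, so it remains open whether any group there can move this read-out at all. A methoxy group, a nitrile or an amine in that place is not covered by these results.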